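The compounds below may be only part of what the source reports. "The series", "measured", "known", "first", "only" and "open" are said of these compounds alone.

Of the compounds shown here, two have been measured so far. In a functional assay on MGC-803 cells (Homo sapiens) for inhibition, read by MTT assay, with a stated time of 72 h (on this read-out higher numbers stand for weaker inhibition and lower numbers for stronger inhibition), compound 1 (`Cc1ccc(N2CCCC2)c(C(=O)Nc2ccc(CNC(=O)OCc3cccnc3)cc2)c1`) gives 19100 nM and compound 2 (`O=C(NCc1ccc(NC(=O)c2ccc(F)cc2N2CCCC2)cc1)OCc1cccnc1`) gives 52100 nM. Compound 2 therefore holds the higher of the two numbers, which makes it the weaker inhibitor of the pair, and its gap to compound 1 lies beyond the scatter.

Compound 3 (`Cc1ccc(C(=O)Nc2ccc(CNC(=O)OCc3cccnc3)cc2)c(N2CCCC2)c1`) keeps everything in compound 2 except one place. It has methyl in place of fluoro on an aromatic carbon, meta to a pyrrolidin-1-yl group and para to a large group (methyl in place of fluoro on an aromatic carbon). Going by the values given here, the series offers no measured step for this exchange, so any expectation remains loose. Among the compounds with values here, with compound 1 at 19100 nM as the only lower number in this assay, a small shift toward stronger inhibition is expected, though it may not clear the scatter. The expected step is a 1.6-fold lower number from compound 2 to compound 3 (0.20 log units; within the scatter), and this estimate leaves open that no real change appears. For compound 3 the estimated value is 33000 nM, with an expected range from 13000 nM to 70000 nM.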

Compound 3, half-maximal inhibitory concentration: > 100000 nM
Compound 3 gave a limit, no number; the forecaster's own chance of this, stated with the estimate: 10%; at least 3.0-fold (0.48 log units) between middle value and limit.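

In this assay, going by these compounds alone, compound 3 reaches > 100000 nM, which is a limit of the assay and not a number, so its true value stays unknown: the limit of > 100000 nM in this assay, at which 1 of the 3 values shown sits. The first measured exchange at this aromatic carbon, meta to a pyrrolidin-1-yl group and para to a large group, gives an at least 1.9-fold higher number from compound 2 to compound 3 (0.28 log units; that floor lies within the scatter), which means that methyl in place of fluoro brought no stronger inhibition here, although the real size of the step may be larger than this floor. Fluoro and methyl each count one heavy atom, with no ring, no hydrogen-bond donor or acceptor and no net charge, so a swap that leaves these counts unchanged still failed to give a measurable gain at this position.

The compounds shown do not tell how far past the limit compound 3 lies, and with only this one exchange at this carbon they give no trend for the position. On these data alone, how a methoxy group, a nitrile, an amine or plain hydrogen on this same carbon would read in this assay stays open.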